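Notes on a chalcone–triazole series: methoxy removal

The compounds below may be only part of what the source reports. "The series", "measured", "known", "first", "only" and "open" are said of these compounds alone.

The series shares one core, seen in compound 1 `O=C(CBr)Nc1ccc(C(=O)/C=C/c2cn(Cc3ccc(Br)cc3)nn2)cc1`, compound 2 `CCCCCCCCn1cc(/C=C/C(=O)c2ccc(NC(=O)CN3CCN(c4ccccc4)CC3)cc2)nn1` and compound 3 `COc1ccccc1N1CCN(CC(=O)Nc2ccc(C(=O)/C=C/c3cn(Cc4ccc(Br)cc4)nn3)cc2)CC1`. In a functional assay on MCF7 cells (Homo sapiens) for inhibition, read by MTT assay (a higher number here means a weaker inhibitor, a lower number a stronger inhibitor), compound 1 gives 10100 nM. Compound 2 gives 31900 nM in this assay, and compound 3 gives 36800 nM. Compound 3 thus carries the highest of the three numbers; its nearest neighbour is compound 2, whose value sits within the scatter of it, while compound 1 lies beyond the scatter and shows the lower number of the pair.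

The next compound, compound 4 `O=C(CN1CCN(c2ccccc2)CC1)Nc1ccc(C(=O)/C=C/c2cn(Cc3ccc(Br)cc3)nn2)cc1`, differs from compound 3 in one place only: hydrogen in place of methoxy on an aromatic carbon. Among the compounds with values here, no measured pair in the set shows this change on its own, so its effect cannot be read off directly. Compound 2, which also carries a phenylpiperazine without a methoxy, is within the scatter of compound 3, although its triazole substituent is different, so that comparison is only indirect.

The step of a 1.2-fold lower number from compound 3 to compound 4 (0.09 log units; within the scatter) is expected to be small, with no clear direction beyond the scatter. Compound 4 is estimated at 30000 nM in this assay, with a likely range from 12000 nM to 75000 nM.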

Compound 4, half-maximal inhibitory concentration: 49200 nM
Estimate against measurement, compound 4: 1.6-fold (0.21 log units) below, and the stated range covers the measured number.
By their numbers in this assay, from the lowest: compound 1; then compounds 2, 3 and 4 (each within the scatter of the next).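

Hydrogen in place of methoxy on an aromatic carbon, ortho to a large group, can now be read as a direct pair in this assay (a 1.3-fold higher number from compound 3 to compound 4 (0.13 log units; within the scatter)), so going from 2-methoxyphenyl to phenyl leaves no effect that can be told from the scatter at this position. Within the data shown here, with phenyl in place, 4-bromophenyl in place of heptyl on a saturated chain carbon bound to an aromatic nitrogen is also within the scatter (a 1.5-fold higher number from compound 2 to compound 4 (0.19 log units; within the scatter)), whereas 4-phenylpiperazin-1-yl in place of bromo on a saturated chain carbon bound to a carbonyl carbon is the only one of these steps beyond it (a 4.9-fold higher number from compound 1 to compound 4 (0.69 log units; beyond the scatter)). Nothing in hand accounts for any of these three steps.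

A single pair leaves open whether other groups on the same aromatic carbon, such as a chloro, a hydroxyl or a carboxylic acid, would also stay within the scatter of compound 4. From the compounds shown here alone, it is also open whether a simple amine such as dimethylamino in place of the 4-phenylpiperazin-1-yl would stay close to compound 4 or move towards compound 1.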